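A few compounds are considered here, and "the series" means these few. Any claim that something is new, unique, unknown or untested is made for them only; others in the source may bear on it.

Measured so far in a functional assay on the whole organism (strain Albino Wistar) for inhibition, with Rattus norvegicus as the target, read by paw edema, with stated times of 1 h and 3 h, at a dose of 10 mg/kg by the oral route; a higher number here means more inhibition at the dose given (going by the name of the read-out), a lower number less inhibition:
Compound 1 `Clc1ccccc1-n1cc(CSc2nc3ccccc3s2)nn1`: 83.3%
Compound 2 `Clc1ccc(-n2cc(CSc3nc4ccccc4s3)nn2)cc1`: 50%
Compound 3 `Brc1ccc(-n2cc(CSc3nc4ccccc4s3)nn2)cc1`: 75%

Compound 3 stands second highest of the three numbers. Its nearest neighbour is compound 1, and the gap a number 8.3 percentage points lower from compound 1 to compound 3 (within the scatter) lies within the scatter, so these two cannot be ordered. Compound 2 is furthest away, and the step of a number 25 percentage points higher from compound 2 to compound 3 (beyond the scatter) lies beyond the scatter.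

The next compound is compound 4 `CC1(C)OCC(Cn2cc(CSc3nc4ccccc4s3)nn2)O1`. Relative to compound 3 the change is (2,2-dimethyl-1,3-dioxolan-4-yl)methyl in place of 4-bromophenyl on an aromatic nitrogen.

All three measured steps alter the group on the same aromatic nitrogen, so each of them bears on this step, but every one of them exchanges one aryl group for another. a number 33.3 percentage points lower from compound 1 to compound 2 (beyond the scatter) shows that this position can move the read-out by a large amount; a number 25 percentage points higher from compound 2 to compound 3 (beyond the scatter) shows a modest swing between two halogens on the same ring; a number 8.3 percentage points lower from compound 1 to compound 3 (within the scatter) stays within the scatter. For the measured compounds named here, no measured step exchanges the aryl group for a non-aromatic one, so the expected step of a number 17 percentage points lower from compound 3 to compound 4 (beyond the scatter) has no direct precedent in either direction. Given the spread already seen at this position, the expectation is placed near the middle of the measured range with a wide interval. Compound 4 is expected to give 58%, between 30% and 82%.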

Compound 4, a percentage reported as inhibition, in the whole organism at one dose (the size of the read-out at that dose, not a potency): 53.3%
Estimate against measurement, compound 4: 4.7 percentage points above; measured number inside the range.
By their numbers in this assay, from the lowest: compounds 2 and 4 (each within the scatter of the next); then compounds 3 and 1 (each within the scatter of the next).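

In this assay, compound 4 gives 53.3%, so with (2,2-dimethyl-1,3-dioxolan-4-yl)methyl on the aromatic nitrogen, a six-membered aromatic ring at this position is not a condition for inhibition at the dose given. What the exchange costs depends on the aryl group it is set against: the read-out is a number 21.7 percentage points lower from compound 3 to compound 4 (beyond the scatter) and a number 30 percentage points lower from compound 1 to compound 4 (beyond the scatter), yet a number 3.3 percentage points higher from compound 2 to compound 4 (within the scatter), so the non-aromatic group cannot be ranked against the aryl groups as a class. No measurement shown bears on the reason for these steps.

The compounds shown leave open whether the result belongs to the dioxolane ring itself or to any non-aromatic group at this position, a question that a plain cyclohexyl group or an open 2,3-dihydroxypropyl chain would address. They also leave open how the halogen and its place on the ring each contribute among the aryl groups, and a 2-bromophenyl group would complete that comparison.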